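The source may hold more compounds than are shown below. What is called first, only, known or untested is meant among the compounds shown, and "the series" means these compounds.

Measured so far in a toxicity assay on NIH3T3 cells (Mus musculus) for cytotoxicity, read by resazurin assay; a higher number here means that more compound is needed for the effect, a lower number that less compound is needed:
- compound 1 `Cc1ccccc1-c1cccc(NCc2cncn2Cc2ccccc2)c1`: > 1000 nM (a limit of the assay)
- compound 2 `O=[N+]([O-])c1ccc(Cn2cncc2CNc2cccc(-c3ccccc3)c2)cc1`: 10000 nM

Compound 1 gives > 1000 nM, which is a limit and not a number. For the measured compounds named here, compound 2, at 10000 nM, therefore holds the only actual number in this assay so far.

The next compound to be measured is compound 3 `c1ccc(Cn2cncc2CNc2cccc(-c3ccccc3)c2)cc1`. It differs from compound 2 by having hydrogen in place of nitro on an aromatic carbon, para to a large group: hydrogen in place of nitro on an aromatic carbon. Going by the values given here, no measured step covers this change, so the expectation rests on compound 2 at 10000 nM. No change beyond the usual scatter is expected in this assay, and the expected 1.3-fold lower number from compound 2 to compound 3 (0.10 log units; within the scatter) is small. For compound 3 the estimated value is 8000 nM, with an expected range from 2500 nM to 30000 nM.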

Compound 3, half-maximal effective concentration: > 750 nM
Compound 3 gave a limit, no number; the forecaster's own chance of this, stated with the estimate: 35%; the middle value lies beyond the limit too.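

In this assay compound 3 gives > 750 nM, which is a limit of the assay and not a number. Its steps from compound 1 and from compound 2 cannot be read. The compounds shown leave open whether hydrogen in place of nitro on an aromatic carbon changes the number in this assay at all.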